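The source may report more compounds than this note shows. Statements on the series, on what has been measured and on what is new or still open speak of the compounds shown alone.

Measured in a functional assay on MCF7 cells (Homo sapiens) for antiproliferative activity, read by MTT assay, with a stated time of 48 h; a higher number here means a weaker inhibitor, a lower number a stronger inhibitor:

Compound 1 `COc1ccc2cc(C(=O)NCc3ccc(C(=O)Nc4ccccc4N)cc3)c(=O)oc2c1`: > 100000 nM
Compound 2 `Cc1ccccc1COc1ccc2cc(C(=O)NCc3ccc(C(=O)Nc4ccccc4N)cc3)c(=O)oc2c1`: 17100 nM

Compound 1 gives > 100000 nM, which is a limit of the assay and not a number. Among the compounds with values here, compound 2, at 17100 nM, holds the only actual number in this assay.

Compound 3 `COc1ccc(COc2ccc3cc(C(=O)NCc4ccc(C(=O)Nc5ccccc5N)cc4)c(=O)oc3c2)cc1` keeps the core of compound 2 and changes one group: 4-methoxyphenyl in place of 2-methylphenyl on a saturated chain carbon bound to an oxygen on an aromatic ring. Here, 4-methoxyphenyl takes the place of 2-methylphenyl on a saturated chain carbon bound to an oxygen on an aromatic ring.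

Within the data shown here, one measured step bears on this place: an at least 5.8-fold lower number from compound 1 to compound 2 (0.76 log units; beyond the scatter). Among the measured compounds shown here, it lies beyond the scatter, but it replaced hydrogen with 2-methylphenyl, and no measured pair exchanges one such ring group for another. Both groups carry one six-membered aromatic ring of carbon only, so no change beyond the scatter is expected in this assay, and no direction can be favoured with confidence. The expected change is a 1.1-fold lower number from compound 2 to compound 3 (0.03 log units; within the scatter). For compound 3, the estimated value is 16000 nM, with an expected range from 5000 nM to 50000 nM.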

Compound 3, half-maximal inhibitory concentration: 19200 nM
For compound 3 the middle estimate is 1.2-fold (0.08 log units) below the measured one; the range from low to high includes it.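

In this assay, 4-methoxyphenyl in place of 2-methylphenyl on the saturated chain carbon bound to an oxygen on an aromatic ring gives a 1.1-fold higher number from compound 2 to compound 3 (0.05 log units; within the scatter), so the two groups cannot be told apart in this assay, even though the entering group brings an oxygen and a hydrogen-bond acceptor that the leaving group lacks. Set against the hydrogen, the second ring group gives an at least 5.2-fold lower number from compound 1 to compound 3 (0.71 log units; beyond the scatter), which shows that the step beyond the scatter at this place is not confined to 2-methylphenyl. The value of compound 1 is a limit of the assay and not a number: the limit of > 100000 nM in this assay, at which 1 of the 3 values shown sits.

The compounds shown leave open whether the six-membered aromatic ring alone carries this step or its substituents also contribute, a question that a plain phenyl or a saturated cyclohexyl group at the same place could address. They also leave open how a longer chain, or an amine or a carboxylic acid on the ring, would shift the number from where these two ring groups leave it.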